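Nitro to Amino on a Shared Styryl Sulfone Core

The compounds below may be only part of what the source reports. "The series", "measured", "known", "first", "only" and "open" are said of these compounds alone.

Compound 1, `COc1ccc(CS(=O)(=O)/C=C/c2c(OC)cccc2OC)c([N+](=O)[O-])c1`: in a functional assay on DU-145 cells (Homo sapiens) for cytotoxicity, read by trypan blue exclusion, with a stated time of 96 h (on this read-out higher numbers stand for weaker inhibition and lower numbers for stronger inhibition), compound 1 gives 50000 nM.
Compound 2, `COc1ccc(CS(=O)(=O)/C=C/c2c(OC)cccc2OC)c(N)c1`: compound 2 gives 750 nM.
Compound 3, `COc1ccc(CS(=O)(=O)/C=C/c2c(OC)cc(O)cc2OC)cc1[N+](=O)[O-]`: compound 3 gives 5000 nM.

Compound 1 and compound 2 differ in a single place: amino in place of nitro on an aromatic carbon. That change produced a 67-fold lower number from compound 1 to compound 2 (1.82 log units; beyond the scatter).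

Compound 4, `COc1ccc(CS(=O)(=O)/C=C/c2c(OC)cc(O)cc2OC)cc1N`, is not yet measured. It stands to compound 3 as compound 2 stands to compound 1: amino in place of nitro on an aromatic carbon. The surroundings are not identical, though: in compound 1 the group sits ortho to a large group and meta to a methoxy group, whereas in compound 3 it sits ortho to a methoxy group and meta to a large group, so this is the same kind of change rather than the same change. The difference between the two cores is not broken down here.

Because the earlier step gave a 67-fold lower number from compound 1 to compound 2 (1.82 log units; beyond the scatter), a step in the same direction is expected, and the step from compound 3 to compound 4 is estimated at a 50-fold lower number from compound 3 to compound 4 (1.70 log units; beyond the scatter). Compound 4 is therefore expected to give about 100 nM, most likely between 25 nM and 500 nM.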

Compound 4, half-maximal inhibitory concentration: 200 nM
Beside the measured number, compound 4's estimate is 2.0-fold (0.30 log units) below it; measured number inside the range.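

Replacing nitro with amino lowers the number again in this assay, a 25-fold lower number from compound 3 to compound 4 (1.40 log units; beyond the scatter), so the direction of the change carries over to the second core and the step is again large. The size carries over only roughly, and the two steps differ by more than repeated measurements would explain: the same change on two cores in this assay, a 67-fold lower number (1.82 log units; beyond the scatter) from compound 1 to compound 2 and a 25-fold lower number (1.40 log units; beyond the scatter) from compound 3 to compound 4, 2.7-fold (0.43 log units) apart, beyond the scatter of two such steps. Among the compounds shown here, these are only two pairs, and their cores differ in more than one place, so the data cannot say which core difference goes with the gap, nor do they show that the change would act the same way on any further core.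

What an acetamide or a carboxylic acid would do at the same place on the ring remains open, so the compounds shown cannot separate a benefit of the amino group itself from the loss of the nitro group. Also open, going by these compounds, is whether a longer chain on that nitrogen, as in a dimethylamino group, would keep the lower number.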